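The source may report more compounds than this note shows. Statements on the series, on what has been measured and on what is new or still open speak of the compounds shown alone.

Compound 1 `CC/C(=C(/c1ccc(/C=C/C(=O)O)cc1)c1ccn2nccc2c1)c1ccccc1`: > 500 nM
Compound 2 `CC/C(=C(/c1ccc(/C=C/C(=O)O)cc1)c1ccc2nncn2c1)c1ccccc1`: > 500 nM
Compound 3 `CC/C(=C(/c1ccc(/C=C/C(=O)O)cc1)c1ccc2ncsc2c1)c1ccccc1`: > 500 nM

These compounds were tested in a functional assay on MCF7 cells (Homo sapiens) for antiproliferative activity, read by CellTiter-Glo, with a stated time of 5 days; a lower number here means a stronger inhibitor, a higher number a weaker inhibitor. In this test, compound 3 gives > 500 nM, which is a limit and not a number. All the results so far stand at the limit of > 500 nM in this assay, at which 3 of the 3 values shown sit.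

Compound 4 `CC/C(=C(/c1ccc(/C=C/C(=O)O)cc1)c1ccc2sc(C)nc2c1)c1ccccc1` carries 2-methyl-1,3-benzothiazol-5-yl in place of 1,3-benzothiazol-6-yl, on a double-bonded chain carbon bound to an aromatic carbon and a double-bonded chain carbon: 2-methyl-1,3-benzothiazol-5-yl in place of 1,3-benzothiazol-6-yl on a double-bonded chain carbon bound to an aromatic carbon and a double-bonded chain carbon.

Three measured changes at this same place bear on the new one: a step that the two limits leave unreadable from compound 1 to compound 2, a step that the two limits leave unreadable from compound 1 to compound 3 and a step that the two limits leave unreadable from compound 2 to compound 3. None of them has a size that can be read, so they offer no guide to how far, or in which direction, the new change should move the result. Another limit is the likeliest outcome, and no clear gain in potency is expected.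

The expected change is a step that the limit leaves unreadable from compound 3 to compound 4, with neither direction favoured.

The estimate for compound 4 is 800 nM, with an expected range of 200 nM to 3000 nM.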

Compound 4, half-maximal inhibitory concentration: > 500 nM
Compound 4: no number, only a limit; the forecaster's own chance of this, stated with the estimate: 75%; the middle value does not contradict the limit.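

In this assay compound 4 gives > 500 nM, which is a limit and not a number. Its steps from compound 1, compound 2 and compound 3 therefore cannot be read. Left open is how potent any of these compounds is, and whether changing this group alters potency at all, since every result shares one limit: the limit of > 500 nM in this assay, at which 4 of the 4 values shown sit.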